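A Weak Compound and Its Untested Neighbour

The source may report more compounds than this note shows. Statements on the series, on what has been measured and on what is new or still open speak of the compounds shown alone.

In a functional assay on MCF7 cells (Homo sapiens) for antiproliferative activity, read by MTT assay (a lower number here means a stronger inhibitor, a higher number a weaker inhibitor), compound 1 `CC1(C)CCc2c(ccc(C(=O)/C=C/c3ccc(OCc4cn(-c5ccc(Cl)cc5)nn4)cc3)c2O)O1` gives "not active" (no number reported) and compound 2 `CC1(C)CCc2c(ccc(C(=O)/C=C/c3ccc(OCc4cn(-c5ccc(Br)cc5)nn4)cc3)c2O)O1` gives "not active" (no number reported) with no number reported for either. For the measured compounds named here, compound 3 `Cc1c(-n2cc(COc3ccc(/C=C/C(=O)c4ccc5c(c4O)CCC(C)(C)O5)cc3)nn2)cccc1[N+](=O)[O-]` gives 145000 nM as the only number in this small set, so no measured step is available as a guide. Compound 4 `CC(=O)c1ccc(-n2cc(COc3ccc(/C=C/C(=O)c4ccc5c(c4O)CCC(C)(C)O5)cc3)nn2)cc1` keeps the shared core and changes one group (4-acetylphenyl in place of 2-methyl-3-nitrophenyl on an aromatic nitrogen): 4-acetylphenyl in place of 2-methyl-3-nitrophenyl on an aromatic nitrogen. Both groups carry one six-membered aromatic ring of carbon only, and nothing measured shows what this swap does. The expected step of a 1.2-fold lower number from compound 3 to compound 4 (0.08 log units; within the scatter) in this assay is therefore none beyond the usual scatter. Compound 4 is estimated at 120000 nM with an expected range (40000 nM to 300000 nM).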

Compound 4, half-maximal inhibitory concentration: 171000 nM
For compound 4 the middle estimate is 1.4-fold (0.15 log units) below the measured one; the measured number falls inside the stated range.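

In this assay, for the compounds shown here, placing 4-acetylphenyl in place of 2-methyl-3-nitrophenyl on the aromatic nitrogen gives a 1.2-fold higher number from compound 3 to compound 4 (0.07 log units; within the scatter) and so makes no clear difference, the first measured comparison at this position. No measurement shown explains why these two groups give such close values. Steps involving compound 1 or compound 2 cannot be read, as neither has a number.

Going by these compounds, it remains open whether a carboxylic acid or an amine on the phenyl ring at this position would move the value beyond the scatter.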